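This account rests on a few compounds, and the source may have more. Where it says the series, first, only, none or still open, it means among the compounds named here.

Measured so far: compound 1 `CCOC(=O)c1c(-c2ccc(C)cc2)cc(-c2ccccc2)nc1N1CCCCC1`, 175000 nM; compound 2 `CCOC(=O)c1c(-c2ccc(F)cc2)cc(-c2ccccc2)nc1Nc1ccccc1`, 367000 nM; compound 3 `CCOC(=O)c1c(-c2ccc(F)cc2)cc(-c2ccccc2)nc1Nc1ccc(Cl)cc1`, 715000 nM.

In a functional assay on thoracic aorta (strain Wistar) with Aorta (Rattus norvegicus) as the target, with a stated time of 2 h (on this read-out higher numbers stand for weaker inhibition and lower numbers for stronger inhibition), compound 3 stands highest of the three numbers. Among the measured compounds shown here, its nearest neighbour is reached by a 1.9-fold higher number from compound 2 to compound 3 (0.29 log units; within the scatter); compound 1 lies further off, but the two differ in more than one place and no single step links them. Compound 4 `CCOC(=O)c1c(-c2ccc(C)cc2)cc(-c2ccccc2)nc1Nc1ccc(Cl)cc1` is reached from compound 3 by methyl in place of fluoro on an aromatic carbon. For the measured compounds named here, no measured step swaps these two groups, and the only single-place step, the one just given, alters a different substituent and stays within the scatter. The account therefore expects no step beyond the scatter, a 1.2-fold lower number from compound 3 to compound 4 (0.08 log units; within the scatter). Compound 4 is estimated at 600000 nM, within 250000 nM to 1500000 nM.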

Compound 4, half-maximal inhibitory concentration: 266000 nM
Beside the measured number, compound 4's estimate is 2.3-fold (0.35 log units) above it, and the stated range covers the measured number.
By their numbers in this assay, from the lowest: compounds 1, 4, 2 and 3 (each within the scatter of the next, the first and the last beyond it).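

Among the compounds shown here, replacing 4-fluorophenyl with 4-methylphenyl gives a 2.7-fold lower number from compound 3 to compound 4 (0.43 log units; beyond the scatter) and is the first single-place change here to pass the scatter, so this position registers a change that the chloro step did not. With 4-methylphenyl held, the change at the other position gives a 1.5-fold higher number from compound 1 to compound 4 (0.18 log units; within the scatter) and so leaves (4-chlorophenyl)amino and piperidin-1-yl unseparated. No evidence is available that bears on this result.

On these data alone, whether a methoxy group, an amine or a carboxylic acid at this place would shift the number further stays open. So does whether the fluoro-to-methyl swap gives a similar step with piperidin-1-yl on the core.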